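Cyclopentyl for Neopentyl on an Aromatic Oxygen

The source may hold more compounds than are shown below. What is called first, only, known or untested is meant among the compounds shown, and "the series" means these compounds.

In an assay on cells for antagonist activity at transient receptor potential cation channel subfamily V member 1 (Homo sapiens), read by FLIPR and calcium flux, with a stated time of 6 min (on this read-out lower numbers stand for stronger inhibition and higher numbers for weaker inhibition), compound 3 `CC(C(=O)NCc1ccc(C(C)(C)C)cc1OCC(C)(C)C)c1ccc(NS(C)(=O)=O)c(F)c1` gives 3.8 nM, the highest number among the three measured compounds. Compound 1 `CC(C(=O)NCc1ccc(C(C)(C)C)cc1N1CCCCC1)c1ccc(NS(C)(=O)=O)c(F)c1` gives 1.9 nM, and compound 2 `CC(C(=O)NCc1ccc(C(C)(C)C)cc1N1CCN(c2ccccc2)CC1)c1ccc(NS(C)(=O)=O)c(F)c1` gives 0.8 nM. The step of a 2.0-fold higher number from compound 1 to compound 3 (0.30 log units; within the scatter) stays within the scatter, while a 4.8-fold higher number from compound 2 to compound 3 (0.68 log units; beyond the scatter) and a 2.4-fold lower number from compound 1 to compound 2 (0.38 log units; beyond the scatter) lie beyond it, so only compound 2 stands clearly apart from compound 3.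

Compound 4 `CC(C(=O)NCc1ccc(C(C)(C)C)cc1OC1CCCC1)c1ccc(NS(C)(=O)=O)c(F)c1` differs from compound 3 by cyclopentyl in place of neopentyl on an oxygen on an aromatic ring. Within the data shown here, no measured step alters this group while keeping the oxygen: the measured steps of a 2.0-fold higher number from compound 1 to compound 3 (0.30 log units; within the scatter) and a 4.8-fold higher number from compound 2 to compound 3 (0.68 log units; beyond the scatter) exchange the whole neopentyloxy group for piperidin-1-yl or 4-phenylpiperazin-1-yl, and even these larger exchanges shift the number only modestly. Since compound 4 keeps the oxygen and carries a group with the same count of heavy atoms, the step in this assay is expected to be small, possibly within the scatter, with a slight lean toward a lower number. Compound 4 is therefore estimated to give 3 nM, with a range from 1.2 nM to 8 nM. The expected step is a 1.3-fold lower number from compound 3 to compound 4 (0.10 log units; within the scatter).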

Compound 4, inhibition constant: 1.8 nM
The estimate for compound 4 lay 1.7-fold (0.22 log units) above the measured number, within the range that was stated.
By their numbers in this assay, from the lowest: compound 2; then compounds 4, 1 and 3 (each within the scatter of the next, the first and the last beyond it).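

Keeping the oxygen and the count of heavy atoms, but replacing the open neopentyl chain with the cyclopentyl ring, still moves the number in this assay slightly past the scatter (a 2.1-fold lower number from compound 3 to compound 4 (0.32 log units; beyond the scatter)), so this position responds even to a change of this kind. The cyclopentyloxy and piperidin-1-yl groups cannot be told apart here (a 1.1-fold lower number from compound 1 to compound 4 (0.02 log units; within the scatter)), whereas the 4-phenylpiperazin-1-yl group remains distinct from cyclopentyloxy (a 2.3-fold higher number from compound 2 to compound 4 (0.35 log units; beyond the scatter)). Nothing available explains these differences.

On these data alone, it remains open whether a smaller cyclopropyl ring or a larger cyclohexyl ring on the same oxygen would shift the number further. The effect of adding a hydroxyl group or an amine to the cyclopentyl ring is also unknown.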